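Amide-linked pyridine N-oxide piperidines: agonist activity at the dopamine receptor

The source may report more compounds than this note shows. Statements on the series, on what has been measured and on what is new or still open speak of the compounds shown alone.

Measured so far:
compound 1, `Cc1cc(NC(=O)CN2CCC(c3cccc[n+]3[O-])CC2)ccc1F`: 18 nM
compound 2, `Cc1cccc(C(=O)NCN2CCC(c3cccc[n+]3[O-])CC2)c1`: 89 nM

In a functional assay on HEK293 cells for agonist activity at D(4) dopamine receptor (Homo sapiens), read by FLIPR (on this read-out lower numbers stand for an effect already at smaller amounts and higher numbers for an effect only at larger amounts of compound), compound 1 gives 18 nM, the lowest of the two numbers recorded. Among the compounds with values here, compound 2 gives 89 nM in this assay, a number beyond the scatter above that of compound 1; compound 2 differs from compound 1 in more than one place, so the two values are compared only as they stand and no single step is drawn between them.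

Compound 3, `O=C(CN1CCC(c2cccc[n+]2[O-])CC1)Nc1ccccc1F`, has not been measured in this assay. It arises from compound 1 by the change (2-fluorophenyl in place of 4-fluoro-3-methylphenyl on an amide-type nitrogen). Within the data shown here, no measured pair isolates this kind of change, so the expectation rests on compound 1 alone. A modest move toward a higher number is expected, with a 2.8-fold higher number from compound 1 to compound 3 (0.44 log units; beyond the scatter) as the estimated step; a result within the scatter of compound 1 cannot be ruled out. Compound 3 is expected to give 50 nM in this assay, within a range from 15 nM to 200 nM.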

Compound 3, half-maximal effective concentration: 270 nM
The estimate for compound 3 lay 5.4-fold (0.73 log units) below the measured number, and the stated range ends below it.
By their numbers in this assay, from the lowest: compound 1; then compound 2; then compound 3.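

In this assay, within the data shown here, the replacement of 4-fluoro-3-methylphenyl by 2-fluorophenyl on the amide-type nitrogen gives a 15-fold higher number from compound 1 to compound 3 (1.18 log units; beyond the scatter) and is the first single-place step. The aryl group on this nitrogen is thus a sensitive place: the read-out moves strongly although both groups hold one six-membered aromatic ring of carbon only, with no hydrogen-bond donors or acceptors and no net charge. No evidence at hand bears on the cause of this step.

The two aryl groups differ in both the methyl and the place of the fluorine, so the compounds shown do not assign the step to either. Going by these compounds, a 4-fluorophenyl or 3-methylphenyl group on the same nitrogen would divide it, and how a cyclohexyl group behaves there remains open.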